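The compounds below may be only part of what the source reports. "The series", "measured", "known", "first", "only" and "open" are said of these compounds alone.

Three compounds built on a shared core have numbers in a functional assay on NCI-H2228 cells (Homo sapiens) for inhibition, read by CellTiter-Glo, with a stated time of 96 h; on this read-out higher numbers stand for weaker inhibition and lower numbers for stronger inhibition. Compound 1 `Cc1cc(Nc2ncc(Cl)c(Nc3cn(C)nc3S(=O)(=O)C(C)C)n2)c(OC2CC2)cc1C(=O)C(C)C` gives 149 nM, compound 3 `CC(C)S(=O)(=O)c1nn(C)cc1Nc1nc(Nc2cc(Cl)c(C3CCN(C)CC3)cc2OC2CC2)ncc1Cl` gives 103 nM, and compound 2 `Cc1cc(Nc2ncc(Cl)c(Nc3cn(C)nc3S(=O)(=O)C(C)C)n2)c(OC2CC2)cc1C1CCCN(C)C1` gives 32 nM, the lowest number of the three. Compound 4 `Cc1cc(Nc2ncc(Cl)c(Nc3cn(C)nc3S(=O)(=O)C(C)C)n2)c(OC2CC2)cc1C1COC1` departs from compound 2 in one place, with oxetan-3-yl in place of 1-methylpiperidin-3-yl on an aromatic carbon. Among the measured compounds shown here, only one measured step touches this same place, a 4.7-fold lower number from compound 1 to compound 2 (0.67 log units; beyond the scatter), a modest change that puts 1-methylpiperidin-3-yl in place of isopropylcarbonyl. Compound 3 differs from compound 2 in more than one place, so it offers no clean comparison. For the measured compounds named here, no measurement yet shows oxetan-3-yl on this core, which leaves the size of the step uncertain. Compound 4 gives up 1-methylpiperidin-3-yl, so a return toward compound 1 at 149 nM is expected, to a higher number and weaker inhibition. The expected change is a 4.1-fold higher number from compound 2 to compound 4 (0.61 log units; beyond the scatter). For compound 4 the estimate is 130 nM, with an expected range from 45 nM to 400 nM.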

Compound 4, half-maximal inhibitory concentration: 44 nM
Estimate against measurement, compound 4: 3.0-fold (0.47 log units) above, outside the stated range (below it).
By their numbers in this assay, from the lowest: compounds 2 and 4 (each within the scatter of the next); then compounds 3 and 1 (each within the scatter of the next).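

In this assay, the swap to oxetan-3-yl, a ring with fewer heavy atoms and an oxygen where 1-methylpiperidin-3-yl has a nitrogen, gives a step within the usual scatter (a 1.4-fold higher number from compound 2 to compound 4 (0.14 log units; within the scatter)), so the two rings cannot be told apart at this aromatic carbon. The step away from isopropylcarbonyl is beyond the scatter (a 3.4-fold lower number from compound 1 to compound 4 (0.53 log units; beyond the scatter)), which shows that, on this core, a lower number than that of compound 1 does not require the 1-methylpiperidin-3-yl group. Nothing available explains why these two different rings give results this close.

From the compounds shown here alone, whether this position needs a ring at all remains open, and a straight propyl chain, a simple aminomethyl group or a carboxylic acid at this carbon would test that. Also open, going by these compounds, is how other rings, such as cyclopropyl or morpholine, would compare here.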